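From pyridin-3-yl to pyridin-2-yl on the sulfonyl sulfur

The source may report more compounds than this note shows. Statements on the series, on what has been measured and on what is new or still open speak of the compounds shown alone.

Three sulfonyl variants of the shared core have been read so far in a physicochemical assay for lipophilicity, read by HPLC, at pH 7.4 (on this read-out higher numbers stand for higher lipophilicity and lower numbers for lower lipophilicity), on this scale. Compound 1 (`CNCc1cc(-c2cccnc2F)n(S(=O)(=O)c2cccc(C#N)c2)c1`) carries 3-cyanophenyl and gives -0.36 on this scale. Compound 2 (`CNCc1cc(-c2cccnc2F)n(S(=O)(=O)c2ccoc2)c1`) carries furan-3-yl and gives -1.31 on this scale. Compound 3 (`CNCc1cc(-c2cccnc2F)n(S(=O)(=O)c2cccnc2)c1`) carries pyridin-3-yl and gives -0.85 as the middle number of the three. The steps of a number 0.49 log units lower from compound 1 to compound 3 (beyond the scatter) and a number 0.46 log units higher from compound 2 to compound 3 (beyond the scatter) place it there.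

Compound 4 (`CNCc1cc(-c2cccnc2F)n(S(=O)(=O)c2ccccn2)c1`) is still unmeasured, and the change is pyridin-2-yl in place of pyridin-3-yl on a sulfonyl sulfur with the same atoms joined differently. Those steps and a number 0.95 log units lower from compound 1 to compound 2 (beyond the scatter) as well each replace one ring by a different one. For the measured compounds named here, no measured step keeps the atoms and only rejoins them, so these steps serve only as a loose outer guide. A smaller step is expected here, with no direction favoured. The estimated step is a number 0.05 log units lower from compound 3 to compound 4 (within the scatter) and so no shift beyond the scatter is expected. For compound 4 the estimated value is -0.9 with an expected range from -1.3 to -0.5 on this scale.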

Compound 4, distribution coefficient: 0.05
For compound 4 the middle estimate is 0.95 log units below the measured one, outside the stated range (above it).
By their numbers in this assay, from the lowest: compound 2; then compound 3; then compound 1; then compound 4.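

In this assay, pyridin-2-yl in place of pyridin-3-yl on a sulfonyl sulfur gives a number 0.90 log units higher from compound 3 to compound 4 (beyond the scatter), so at this position rejoining the same atoms can move the read-out by a step beyond the scatter. For the compounds shown here, no earlier step could show this. Each of those exchanged one ring for a different one. Compound 4 also holds the highest number of the four, with a number 0.41 log units higher from compound 1 to compound 4 (beyond the scatter) and a number 1.36 log units higher from compound 2 to compound 4 (beyond the scatter), so the order among these sulfonyl groups does not follow from the ring type alone: the two pyridinyl isomers fall on either side of 3-cyanophenyl. Nothing shown gives a reason for this shift.

From the compounds shown here alone, whether pyridin-4-yl on the same sulfur would read closer to pyridin-2-yl or to pyridin-3-yl remains open. Also open, going by these compounds, is whether a methoxy group or an amine on the pyridin-2-yl ring would keep the number this high.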